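Dropping the fluoro group from compound 3

A few compounds are considered here, and "the series" means these few. Any claim that something is new, unique, unknown or untested is made for them only; others in the source may bear on it.

Four compounds share one core and differ only in the pyridinyl group on the ether oxygen. In an ADME assay on the whole organism (plasma, Rattus norvegicus) for protein binding, using cassette dosing, at a dose of 1 mg/kg (a lower number here means a smaller unbound share, a higher number a larger unbound share of the compound), compound 1 `C[C@@H](Cn1c(=O)[nH]/c(=N\c2ccc(Oc3cncc(F)c3)cc2)n(Cc2ccc(Cl)cc2)c1=O)C(=O)O` gives 0.02, compound 2 `C[C@@H](Cn1c(=O)[nH]/c(=N\c2ccc(Oc3ccc(F)cn3)cc2)n(Cc2ccc(Cl)cc2)c1=O)C(=O)O` gives 0.011 and compound 3 `C[C@@H](Cn1c(=O)[nH]/c(=N\c2ccc(Oc3cccc(F)n3)cc2)n(Cc2ccc(Cl)cc2)c1=O)C(=O)O` gives 0.007. Compound 3 therefore stands apart from only one of the others: the data show a 2.9-fold lower number from compound 1 to compound 3 (0.46 log units; beyond the scatter), but also a 1.6-fold lower number from compound 2 to compound 3 (0.20 log units; within the scatter). The remaining comparison is a 1.8-fold lower number from compound 1 to compound 2 (0.26 log units; within the scatter).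

Compound 4 `C[C@@H](Cn1c(=O)[nH]/c(=N\c2ccc(Oc3ccccn3)cc2)n(Cc2ccc(Cl)cc2)c1=O)C(=O)O` differs from compound 3 by hydrogen in place of fluoro on an aromatic carbon. This places hydrogen in place of fluoro on an aromatic carbon, next to the ring nitrogen. For the measured compounds named here, no measured step removes a fluoro group, so the evidence is indirect. These steps only exchange one fluoropyridinyl group for another, and the closest one, between the two pyridin-2-yl compounds, is a 1.6-fold lower number from compound 2 to compound 3 (0.20 log units; within the scatter). A small move to a higher number, within the scatter, is therefore expected. The estimated step is a 1.6-fold higher number from compound 3 to compound 4 (0.20 log units; within the scatter). For compound 4 the expected unbound fraction is 0.011, with an estimated range of 0.006 to 0.02.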

Compound 4, unbound fraction: 0.01
Estimate against measurement, compound 4: 1.1-fold (0.04 log units) above; low and high end bracket the measured number.
By their numbers in this assay, from the lowest: compounds 3, 4, 2 and 1 (each within the scatter of the next, the first and the last beyond it).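

Taking the fluoro group off the aromatic carbon next to the ring nitrogen gives a direct reading of this change in this assay: a 1.4-fold higher number from compound 3 to compound 4 (0.15 log units; within the scatter), so at this position the data do not separate fluoro from hydrogen. The pyridin-2-yl group of compound 4 also stays within the scatter of the other two fluoropyridinyl compounds, with a 1.1-fold lower number from compound 2 to compound 4 (0.04 log units; within the scatter) and a 2.0-fold lower number from compound 1 to compound 4 (0.30 log units; within the scatter), whereas compound 3 alone lies beyond the scatter of compound 1. Nothing measured here offers an explanation for these numbers.

The compounds shown leave open whether a methyl, a methoxy or a chlorine at this carbon would move the number in this assay beyond the scatter. They also leave open how a pyridin-3-yl group without fluoro would compare with compound 1.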